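Chloro in Place of Methyl on a Shared Core

The source may report more compounds than this note shows. Statements on the series, on what has been measured and on what is new or still open speak of the compounds shown alone.

Within the data shown here, compound 1 `Cc1ccc(-c2n[nH]c3c2CCNCC3)cc1` stands at the higher of the two numbers so far in an assay on cells for displacement of a labelled ligand from 5-hydroxytryptamine receptor 1D (Homo sapiens), read by scintillation counting, with a stated time of 1.5 h (a lower number here means a stronger inhibitor, a higher number a weaker inhibitor), where compound 1 gives 165 nM. Its nearest neighbour is compound 2 `Cc1ccc(-c2noc3c2CCNCC3)cc1`, which in this assay gives 147 nM; the two values lie within the usual scatter of this kind of measurement, so nothing separates them. Among the measured compounds shown here, no step between two measured compounds that differ in one place is available for guidance. Compound 3 `Clc1ccc(-c2n[nH]c3c2CCNCC3)cc1` differs from compound 1 by chloro in place of methyl on an aromatic carbon. For the measured compounds named here, with no comparable measured step to lean on, the change from compound 1 to compound 3 is expected to stay within the scatter, leaning in neither direction. Compound 3 is therefore estimated at 150 nM, with a range from 60 nM to 400 nM. That estimate means a step of a 1.1-fold lower number from compound 1 to compound 3 (0.04 log units; within the scatter), expected to be small.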

Compound 3, inhibition constant: 2110 nM
Compound 3: middle estimate off by 14-fold (1.15 log units), on the low side; the whole stated range lies below it.
By their numbers in this assay, from the lowest: compounds 2 and 1 (each within the scatter of the next); then compound 3.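

In this assay, chloro in place of methyl on an aromatic carbon, para to a large group, gives a 13-fold higher number from compound 1 to compound 3 (1.11 log units; beyond the scatter), so this position responds strongly to a change of a single heavy atom. Compound 1 and compound 2 both carry methyl here and could not show this; the two groups are alike in heavy atom count, hydrogen-bond donors, hydrogen-bond acceptors and net charge, so those counts do not separate them. Nothing measured here bears on why the step is so large.

As far as these compounds go, it remains open whether the weaker binding is specific to chloro or would also appear with fluoro, methoxy or an amine at this place. From the compounds shown here alone, it is also open whether chloro in place of methyl would give a step of similar size on the core of compound 2.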